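Compound 1 and a new hydroxy group

This account rests on a few compounds, and the source may have more. Where it says the series, first, only, none or still open, it means among the compounds named here.

Within the data shown here, in a functional assay on BT-549 cells (Homo sapiens) for inhibition (a lower number here means a stronger inhibitor of growth, a higher number a weaker inhibitor of growth), compound 1 (`COc1ccc(-n2cnnc2-c2cc(OC)c(OC)c(OC)c2)cc1`) stands at 9770 nM and holds the lower of the two numbers so far. Compound 2 (`COc1cc(-c2nncn2-c2ccc(N(C)C)cc2)cc(OC)c1OC`) stands at 25100 nM in the same measurement. Among the measured compounds shown here, the only measured step, a 2.6-fold higher number from compound 1 to compound 2 (0.41 log units; beyond the scatter), is modest and comes from dimethylamino in place of methoxy on an aromatic carbon.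

Compound 3 (`COc1ccc(-n2cnnc2-c2cc(OC)c(OC)c(OC)c2)cc1O`) differs from compound 1 by hydroxy in place of hydrogen on an aromatic carbon, ortho to a methoxy group and meta to a large group (hydroxy in place of hydrogen on an aromatic carbon).

For the measured compounds named here, the measured step involves a different change, and no measured compound carries a hydroxy. It therefore offers a rough scale but no direction. As a tentative judgement, a lower number is expected, with an estimated step of a 6.5-fold lower number from compound 1 to compound 3 (0.81 log units; beyond the scatter) in this assay at wide margins. For compound 3 the expected value is 1500 nM (estimated range 100 nM to 10000 nM).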

Compound 3, concentration for 50% growth inhibition: 3630 nM
Compound 3: the middle estimate sits 2.4-fold (0.38 log units) below what was measured; low and high end bracket the measured number.
By their numbers in this assay, from the lowest: compound 3; then compound 1; then compound 2.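

Hydroxy in place of hydrogen on an aromatic carbon, ortho to a methoxy group and meta to a large group, gives a 2.7-fold lower number from compound 1 to compound 3 (0.43 log units; beyond the scatter) in this assay. Among these compounds, this is the first measured step toward a lower number, since the only earlier one, a 2.6-fold higher number from compound 1 to compound 2 (0.41 log units; beyond the scatter), ran upward and came from a different change, so this place on the core of compound 1 accepts an added oxygen without a rise in the number. No measurement of any property bears on why the number falls.

The compounds shown leave open whether a methoxy, an amine or a fluorine at this same place would match the hydroxy. Also open, on these data alone, is whether the hydroxy gives a similar step on compound 2, which carries dimethylamino in place of the methoxy.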